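The source may hold more compounds than are shown below. What is called first, only, known or untested is meant among the compounds shown, and "the series" means these compounds.

Measured compounds:
compound 1 `O=Cc1ccc(-c2cn3ccnc3c(-c3ccc4ncn(C5CCCCC5)c4c3)n2)cc1` — in a functional assay on MOLT-4 cells (Homo sapiens) for inhibition, read by sulforhodamine B assay, with a stated time of 48 h, tested at 10 uM (a higher number here means more inhibition at the concentration tested (going by the name of the read-out), a lower number less inhibition), compound 1 gives 58.7%
compound 2 `CCc1ccc(-c2cn3ccnc3c(-c3ccc4ncn(Cc5ccccc5)c4c3)n2)cc1` — in this assay compound 2 gives 54.2%
compound 3 `Cc1cccc(-c2cn3ccnc3c(-c3ccc4ncn(Cc5ccccc5)c4c3)n2)c1` — in this assay compound 3 gives 36.9%

Compound 3 stands lowest of the three numbers: compound 2 sits nearest, and the step of a number 17.3 percentage points lower from compound 2 to compound 3 (beyond the scatter) lies beyond the scatter, while compound 1 sits furthest from it, also beyond the scatter. Compound 4 `O=Cc1ccc(-c2cn3ccnc3c(-c3ccc4ncn(Cc5ccccc5)c4c3)n2)cc1` has not yet been measured in this assay. It differs from compound 3 in one place: 4-formylphenyl in place of 3-methylphenyl on an aromatic carbon. Among the compounds with values here, the only measured step that bears on the same place is the one from compound 2 to compound 3, where exchanging a para-substituted phenyl for the 3-methylphenyl lowered the number by a number 17.3 percentage points lower from compound 2 to compound 3 (beyond the scatter). Compound 1 carries the same 4-formylphenyl that enters here, though on a core with a cyclohexyl rather than a benzyl group, and its value is close to that of compound 2. Compound 4 is therefore expected to move back upward, by about a number 17.1 percentage points higher from compound 3 to compound 4 (beyond the scatter). The estimate for compound 4 in this assay is 54%, with a range from 40% to 68%.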

Compound 4, a percentage reported as inhibition, at one concentration (the size of the read-out at that concentration, not a potency): 58.7%
Beside the measured number, compound 4's estimate is 4.7 percentage points below it, and the stated range covers the measured number.
By their numbers in this assay, from the lowest: compound 3; then compounds 2, 1 and 4 (each within the scatter of the next).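

In this assay, 4-formylphenyl in place of 3-methylphenyl gives a number 21.8 percentage points higher from compound 3 to compound 4 (beyond the scatter), so at this position on the shared core the low number of compound 3 does not carry over to every aryl group. Formyl in place of ethyl gives a number 4.5 percentage points higher from compound 2 to compound 4 (within the scatter), so these two groups cannot be told apart here, and compound 3 remains the only one of the four set apart by a step beyond the scatter. Benzyl in place of cyclohexyl on the aromatic nitrogen gives no change at the digits printed from compound 1 to compound 4 (within the scatter), so with 4-formylphenyl present, the two groups at that nitrogen also cannot be told apart.

Nothing available explains these steps. On these data alone, it remains open whether the lower number of compound 3 goes with its methyl group or with where that group sits on the phenyl ring, and how a phenyl ring carrying an amine or a carboxylic acid would read.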